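A few compounds are considered here, and "the series" means these few. Any claim that something is new, unique, unknown or untested is made for them only; others in the source may bear on it.

Measured so far in an assay on isolated protein for inhibition of activin receptor type-2A (Homo sapiens), read by 33P incorporation, with a stated time of 20 min, in the presence of a further agent that is not named here; a lower number here means a stronger inhibitor, a higher number a weaker inhibitor:

- compound 1 `CNc1nc2c(-c3ccnc(OC)c3)cnn2cc1C1CC1` gives 630 nM
- compound 2 `COc1cc(-c2cnn3cc(OC)c(C4CCOC4)nc23)ccn1` gives 1900 nM
- compound 3 `Cn1cc(-c2nc3c(-c4ccnc(OC5CC5)c4)cnn3cc2OCCCC(C)(C)O)cn1` gives 2900 nM

Compound 2 stands second highest of the three numbers. Its nearest neighbour is compound 3, whose number sits within the usual scatter of that of compound 2, so no order between the two is claimed. Compound 1 gives a number that lies beyond the scatter below compound 2; compound 1 differs from compound 2 in more than one place, so it offers only loose guidance.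

Compound 4 `COc1cc(-c2cnn3cc(OC)c(N(C)C)nc23)ccn1` has not been measured. It differs from compound 2 in one place: dimethylamino in place of oxolan-3-yl on an aromatic carbon. Among the measured compounds shown here, no pair of measured compounds shows this change, so there is no measured step to lean on. The expectation for this assay is no step beyond the scatter, or at most a small one toward a lower number, which is what the estimated step of a 1.3-fold lower number from compound 2 to compound 4 (0.10 log units; within the scatter) expresses. Compound 4 is therefore estimated at 1500 nM, with a range from 500 nM to 5000 nM.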

Compound 4, half-maximal inhibitory concentration: 3000 nM
Beside the measured number, compound 4's estimate is 2.0-fold (0.30 log units) below it; measured number inside the range.
By their numbers in this assay, from the lowest: compound 1; then compounds 2, 3 and 4 (each within the scatter of the next).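

In this assay, dimethylamino in place of oxolan-3-yl on the aromatic carbon next to the ring nitrogen gives a 1.6-fold higher number from compound 2 to compound 4 (0.20 log units; within the scatter). With the methoxy group and the rest of the shared core held constant, this single pair therefore shows no readable difference between a five-membered non-aromatic ring and a group with no ring at this position. Nothing measured here bears on why the two groups read alike.

Neither group has a hydrogen-bond donor, so the compounds shown leave open whether a primary amine or a carboxylic acid at this position would give a step beyond the scatter. Also open, on these data alone, is whether the same exchange would read alike on a compound with a different group in place of the methoxy group.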